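Moving the carboxyl and adding fluorine: compound 2 to compound 4

The compounds below may be only part of what the source reports. "The series", "measured", "known", "first", "only" and "open" are said of these compounds alone.

Measured in an ADME assay on the whole organism (plasma) for pharmacokinetics, with Rattus norvegicus as the target, at a dose of 20 mg/kg by the oral route; a higher number here means more compound in the circulation at the dose given, a lower number less compound in the circulation:
- compound 1 `COc1cc(C(=O)O)ccc1OCCCCOc1ccc(C(=O)CC(C)C)c(O)c1C` gives 9140 ng.h/mL
- compound 2 `Cc1c(OCCCCOc2ccc(C(=O)O)cc2)ccc(C(=O)CC(C)C)c1O` gives 3640 ng.h/mL
- compound 3 `COc1ccc(C(=O)O)cc1OCCCCOc1ccc(C(=O)CC(C)C)c(O)c1C` gives 3340 ng.h/mL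

Compound 2 lies within the scatter of compound 3, while compound 1 stands higher, beyond the scatter. The next change leads to compound 4 `Cc1c(OCCCCOc2ccc(F)c(C(=O)O)c2)ccc(C(=O)CC(C)C)c1O` and reads (3-carboxy-4-fluorophenyl in place of 4-carboxyphenyl on an oxygen on a saturated carbon). Among the compounds with values here, only one measured step bears on it, and only loosely: a 2.5-fold lower number from compound 1 to compound 2 (0.40 log units; beyond the scatter), a modest step that concerns a methoxy group, not a fluorine. Within the data shown here, no measurement yet covers fluorine or this new carboxyl placement, so no clear direction can be drawn for this assay and no step beyond the scatter is expected. The expected move is a 1.2-fold lower number from compound 2 to compound 4 (0.08 log units; within the scatter). For compound 4 the estimated value is 3000 ng.h/mL, with a range of 1300 ng.h/mL to 7000 ng.h/mL.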

Compound 4, area under the concentration-time curve: 5030 ng.h/mL
Compound 4: middle estimate off by 1.7-fold (0.22 log units), on the low side; the range from low to high includes it.
By their numbers in this assay, from the lowest: compounds 3, 2, 4 and 1 (each within the scatter of the next, the first and the last beyond it).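

In this assay, 3-carboxy-4-fluorophenyl in place of 4-carboxyphenyl gives a 1.4-fold higher number from compound 2 to compound 4 (0.14 log units; within the scatter), so the two compounds stand level. At this place on the oxygen, the number therefore holds with the carboxyl moved and a fluorine added. No available evidence explains this result.

Both edits arrive together in compound 4, so the shares of the fluorine and the carboxyl placement cannot be separated. On these data alone, whether a chlorine in place of the fluorine, or a tetrazole in place of the carboxylic acid, would hold the number remains open.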